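Swapping Chloro for Trifluoromethyl across Two Related Cores

The source may hold more compounds than are shown below. What is called first, only, known or untested is meant among the compounds shown, and "the series" means these compounds.

compound 1 `O=C1C(=O)N(CN2CCN(c3ccnc4cc(Cl)ccc34)CC2)c2cc(Br)ccc21` — 17600 nM
compound 2 `O=C1C(=O)N(CN2CCN(c3ccnc4cc(C(F)(F)F)ccc34)CC2)c2cc(Br)ccc21` — 28100 nM
compound 3 `NC(=S)N/N=C1/C(=O)N(CN2CCN(c3ccnc4cc(Cl)ccc34)CC2)c2cccc(Cl)c21` — 57500 nM

In a functional assay on MCF7 cells (Homo sapiens) for cytotoxicity, read by sulforhodamine B assay, with a stated time of 48 h (on this read-out lower numbers stand for stronger inhibition of growth and higher numbers for weaker inhibition of growth), the change trifluoromethyl in place of chloro on an aromatic carbon gave a 1.6-fold higher number from compound 1 to compound 2 (0.20 log units; within the scatter). Compound 3 shares the two-ring system carrying the chloro but differs from compound 1 in its core; the difference between the two cores is not broken down here. Among the three measured compounds, compound 3 gives the highest number, beyond the scatter from both others. Compound 4 `NC(=S)N/N=C1/C(=O)N(CN2CCN(c3ccnc4cc(C(F)(F)F)ccc34)CC2)c2cccc(Cl)c21` carries the same change as compound 2, namely (trifluoromethyl in place of chloro on an aromatic carbon), on the core of compound 3. Going by the values given here, since the earlier step from compound 1 to compound 2 stayed within the scatter, compound 4 is expected to sit close to compound 3, with an estimated step of a 1.4-fold higher number from compound 3 to compound 4 (0.14 log units; within the scatter), because the only guide is a 1.6-fold higher number from compound 1 to compound 2 (0.20 log units; within the scatter). Compound 4 is therefore estimated at 80000 nM, expected between 40000 nM and 160000 nM.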

Compound 4, concentration for 50% growth inhibition: 21600 nM
The estimate for compound 4 lay 3.7-fold (0.57 log units) above the measured number; measured number outside the range, below it.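

In this assay, trifluoromethyl in place of chloro on an aromatic carbon gave a 2.7-fold lower number from compound 3 to compound 4 (0.43 log units; beyond the scatter), and this step did not match the one seen on the other core: the same change on two cores in this assay, a 1.6-fold higher number (0.20 log units; within the scatter) from compound 1 to compound 2 and a 2.7-fold lower number (0.43 log units; beyond the scatter) from compound 3 to compound 4, 4.3-fold (0.63 log units) apart, beyond the scatter of two such steps. This shows that, for these two pairs, the step measured on one core was no reliable guide to the step on the other. Going by these compounds alone, it does not show why the steps differ, since each core offers only a single pair and the two cores differ in more than one place.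

The compounds shown leave open which part of the core governs the size and direction of the step. They also leave open how an amine or a methoxy group in place of chloro would behave on either core.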